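This account rests on a few compounds, and the source may have more. Where it says the series, first, only, none or still open, it means among the compounds named here.

In an ADME assay for permeability, using PAMPA, at pH 7.4 (a higher number here means that the compound crosses the layer faster, a lower number that the compound crosses the layer more slowly), compound 1 `O=C(Nc1cccc(-c2nc3ccccc3s2)c1)c1cc([N+](=O)[O-])ccc1Cl` gives 12 10^-6 cm/s. Compound 2 `O=C(Nc1cccc(-c2ccccc2)c1)c1cc([N+](=O)[O-])ccc1Cl` gives no number: "below limit of detection" (no number reported). Compound 2 therefore has no exact place on the scale, and any step away from it cannot be given as a number. Compound 3 `O=C(Nc1cccc(-c2nc3ccccc3o2)c1)c1cc([N+](=O)[O-])ccc1Cl` has not been measured yet. The structural change is a single swap, 1,3-benzoxazol-2-yl in place of phenyl on an aromatic carbon. Going by the values given here, no measured pair shows this swap directly, so the expectation is uncertain. Among the compounds with values here, the only number available as a guide comes from compound 1 at 12 10^-6 cm/s. A large upward step in this assay is expected on going to a measurable value, although another result without a number remains possible. The estimated value for compound 3 is 8 10^-6 cm/s, with an expected range of 2 10^-6 cm/s to 25 10^-6 cm/s.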

Compound 3, apparent permeability: 45 10^-6 cm/s
Compound 3: middle estimate off by 5.6-fold (0.75 log units), on the low side, outside the stated range (above it).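

In this assay, this position now has two numbers that can be compared directly: 1,3-benzoxazol-2-yl in place of 1,3-benzothiazol-2-yl gives a 3.8-fold higher number from compound 1 to compound 3 (0.57 log units; beyond the scatter). Two fused groups that look much alike therefore read differently here, so the exact make-up of the five-membered ring matters at this place on the shared core. Compound 2, with phenyl at the same place, has no number, so its step to compound 3 cannot be read, and no measurement on hand accounts for the differences among these groups.

Going by these compounds alone, with only two numbers, nothing shows how a single-ring group carrying nitrogen, such as pyridine, would read at this place. Also open, as far as these compounds go, is how a simple amine or a carboxylic acid there would compare, and whether the same swap gives a similar step on a different core.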